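Methylsulfonyl to Diethylcarbamoyl: What to Expect for Compound 3

This account rests on a few compounds, and the source may have more. Where it says the series, first, only, none or still open, it means among the compounds named here.

Compound 1 `CCOc1ccc(OC(=O)N2CCC(C(O)(c3ccccc3)c3ccccc3)CC2)cc1`: 1580 nM
Compound 2 `CS(=O)(=O)c1ccc(OC(=O)N2CCC(C(O)(c3ccccc3)c3ccccc3)CC2)cc1`: 141 nM

Within the data shown here, in a functional assay for antagonist activity at Neuropeptide Y receptor type 2 (Homo sapiens) (on this read-out higher numbers stand for weaker inhibition and lower numbers for stronger inhibition), compound 2 gives 141 nM, the lowest of the two numbers so far, with compound 1 as its only neighbour at 1580 nM. Among the measured compounds shown here, the single measured step, an 11-fold lower number from compound 1 to compound 2 (1.05 log units; beyond the scatter), shows that exchanging this one group on the shared core can shift the read-out a long way. Compound 3 `CCN(CC)C(=O)c1ccc(OC(=O)N2CCC(C(O)(c3ccccc3)c3ccccc3)CC2)cc1` differs from compound 2 by diethylcarbamoyl in place of methylsulfonyl on an aromatic carbon. For the measured compounds named here, no measured compound carries diethylcarbamoyl, so that step is only a loose guide; the change is therefore expected to move the number upward, but by less than the measured step. Compound 3 is estimated at 500 nM, with a range from 150 nM to 2000 nM. That estimate corresponds to an expected step of a 3.5-fold higher number from compound 2 to compound 3 (0.55 log units; beyond the scatter).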

Compound 3, half-maximal inhibitory concentration: 220 nM
Estimate against measurement, compound 3: 2.3-fold (0.36 log units) above; measured number inside the range.
By their numbers in this assay, from the lowest: compounds 2 and 3 (each within the scatter of the next); then compound 1.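

Swapping methylsulfonyl for diethylcarbamoyl gives a 1.6-fold higher number from compound 2 to compound 3 (0.19 log units; within the scatter), so on this aromatic carbon the two groups cannot be told apart, even though diethylcarbamoyl has more heavy atoms and no sulfur. Replacing ethoxy with diethylcarbamoyl gives a 7.2-fold lower number from compound 1 to compound 3 (0.86 log units; beyond the scatter), which shows that the gain over ethoxy is not tied to methylsulfonyl alone. Nothing shown here explains why these two groups give such similar numbers. On these data alone, it remains open whether a carboxylic acid or an amine at this place would keep the number as low. As far as these compounds go, whether the two ethyl chains matter is also open, and dimethylcarbamoyl would test that.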